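This account rests on a few compounds, and the source may have more. Where it says the series, first, only, none or still open, it means among the compounds named here.

In a functional assay on NCI/ADR-RES cells (Homo sapiens) for cytotoxicity, read by sulforhodamine B assay, with a stated time of 48 h (a higher number here means a weaker inhibitor of growth, a lower number a stronger inhibitor of growth), two compounds have been measured:
compound 1, `ClCc1ccccc1Cn1cnc2c(Cl)nc(Cl)nc21`, gives 3020 nM
compound 2, `ClCc1cccc(Cn2cnc3c(Cl)ncnc32)c1`, gives 7580 nM

Of these two numbers compound 1 holds the lower one; compound 2 stands a gap above it that lies beyond the usual scatter of repeated runs. Compound 3, `Nc1nc(Cl)c2ncn(Cc3ccccc3CCl)c2n1`, is not yet measured. It is derived from compound 1 by one change: amino in place of chloro on an aromatic carbon. Among the compounds with values here, no measured pair shows this change, so its effect on this assay cannot be read from any known step. The account therefore expects only a modest move, most likely toward a somewhat higher number, and the step from compound 1 to compound 3 is estimated at a 1.7-fold higher number from compound 1 to compound 3 (0.22 log units; within the scatter). On that basis compound 3 is expected to give about 5000 nM in this assay, with a range estimated from 1500 nM to 15000 nM.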

Compound 3, concentration for total growth inhibition: 34700 nM
Compound 3: the middle estimate sits 6.9-fold (0.84 log units) below what was measured; measured number outside the range, above it.
By their numbers in this assay, from the lowest: compound 1; then compound 2; then compound 3.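

Swapping the chloro group for amino on the aromatic carbon between two ring nitrogen atoms brings an 11-fold higher number from compound 1 to compound 3 (1.06 log units; beyond the scatter) in this assay, so this position is far from indifferent to the change. The earlier compounds shown here could not show this, as they formed no pair differing in one place. The step marks amino as a clear loss against chloro in growth inhibition on the core of compound 1, though this rests on a single pair. Nothing available bears on why the step is so large.

As far as these compounds go, it remains open whether the loss is tied to amino itself or follows any replacement of chloro here, which a methoxy or methylamino group at this position would help to separate. Also open, from the compounds shown here alone, is what the chloromethyl group contributes, which a plain methyl group in its place would show.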